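The compounds below may be only part of what the source reports. "The series", "measured", "known", "first", "only" and "open" are said of these compounds alone.

Across this series a shared core bearing a hydroxy group and a carboxy group carries a five-membered aromatic ring, and that ring is what changes. In a functional assay on the whole organism for inhibition, with Rattus norvegicus as the target, read by paw edema (on this read-out higher numbers stand for an effect only at larger amounts of compound and lower numbers for an effect already at smaller amounts), compound 2 `O=C(O)c1ccc(-c2cscn2)cc1O` gives 70 mg/kg. Compound 3 `O=C(O)c1cc(-c2cocn2)ccc1O` gives 110 mg/kg in this assay, a value within the scatter of compound 2. Compound 1 `O=C(O)c1cc(-c2csnn2)ccc1O` reaches only a limit of the assay, > 200 mg/kg in this assay (the limit of > 200 mg/kg in this assay, at which 1 of the 3 values shown sits). For the measured compounds named here, the single measured step, an at least 1.8-fold lower number from compound 1 to compound 3 (0.25 log units; that floor lies within the scatter), stays within the scatter. Compound 4 `O=C(O)c1ccc(-c2ncco2)cc1O` differs from compound 2 by 1,3-oxazol-2-yl in place of 1,3-thiazol-4-yl on an aromatic carbon. Going by the values given here, no measured step exchanges 1,3-thiazol-4-yl for 1,3-oxazol-2-yl, so the expected step of a 1.3-fold higher number from compound 2 to compound 4 (0.11 log units; within the scatter) is small and of uncertain direction. For compound 4 the estimate in this assay is 90 mg/kg, ranging from 40 mg/kg to 200 mg/kg.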

Compound 4, dose for half-maximal effect: > 250 mg/kg
Compound 4: no number, only a limit; the forecaster's own chance of this, stated with the estimate: 15%; middle value at least 2.7-fold (0.44 log units) from the limit.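

For the compounds shown here, the exchange at this place, para to a carboxy group and meta to a hydroxy group, gives the first step that lies beyond the scatter, an at least 3.5-fold higher number from compound 2 to compound 4 (0.55 log units; beyond the scatter). Both rings have the same counts of heavy atoms, hydrogen-bond donors and hydrogen-bond acceptors, so these counts do not separate them. Compound 4 gives a limit, not a number: the limit of > 250 mg/kg in this assay, at which 1 of the 4 values shown sits.

The compounds shown leave open whether the step follows the ring oxygen or the point of attachment. A 1,3-thiazol-2-yl or 1,3-oxazol-4-yl at this same place would separate the two.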